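The compounds below may be only part of what the source reports. "The series", "measured", "known", "first", "only" and "open" are said of these compounds alone.

Compound 1 `CC1CCN(C(=O)C(C)N2CCN(S(=O)(=O)c3ccc(C(C)(C)C)cc3)CC2)CC1` gives in an ADME assay on HepG2 cells (Homo sapiens) for inhibition, with a stated time of 48 h (on this read-out lower numbers stand for an effect already at smaller amounts and higher numbers for an effect only at larger amounts of compound), the limit > 40000 nM.
Compound 2 `CC(C(=O)N1CCN(C)CC1)N1CCN(S(=O)(=O)c2ccc(C(C)(C)C)cc2)CC1` gives in this assay the limit > 40000 nM.
Compound 3 `CC(C(=O)N1CCc2ccccc21)N1CCN(S(=O)(=O)c2ccc(C(C)(C)C)cc2)CC1` gives in this assay the limit > 40000 nM.

All three values are limits of the assay and not numbers: in each case the effect was not reached within the amounts tested. Compound 3 therefore stands at the same limit as compound 1 and compound 2, and nothing separates the three on the numbers shown. The steps between them, a step that the two limits leave unreadable from compound 1 to compound 2, a step that the two limits leave unreadable from compound 1 to compound 3 and a step that the two limits leave unreadable from compound 2 to compound 3, cannot be read, because of the limit of > 40000 nM in this assay, at which 3 of the 3 values shown sit.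

Compound 4 `CC(C(=O)N(C)Cc1ccccc1)N1CCN(S(=O)(=O)c2ccc(C(C)(C)C)cc2)CC1` differs from compound 3 in one place: benzyl(methyl)amino in place of 2,3-dihydro-1H-indol-1-yl on a carbonyl carbon. For the measured compounds named here, no measured step shows what such a change does here. Going by the values given here, the only comparisons at hand are swaps of the group on the carbonyl carbon, and all of them ended at the limit, so neither a direction nor a size can be drawn from them. The expectation for compound 4 in this assay is 60000 nM, with a range from 30000 nM to 120000 nM. That estimate amounts to a step that the limit leaves unreadable from compound 3 to compound 4, meaning no change beyond the scatter is expected, and most likely a further limit rather than a number.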

Compound 4, half-maximal effective concentration: > 40000 nM
Compound 4 gave a limit, no number; the forecaster's own chance of this, stated with the estimate: 85%; the middle value is on the limit's open side.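

In this assay compound 4 gives > 40000 nM as a limit and not a number. No new step can be read from compound 4 to compound 1, compound 2 or compound 3, because all four share one limit: the limit of > 40000 nM in this assay, at which 4 of the 4 values shown sit. The compounds shown leave open whether any group on the carbonyl carbon changes the result in this assay and by how much.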